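The compounds below may be only part of what the source reports. "The series", "measured", "known", "first", "only" and "open" are said of these compounds alone.

Measured in an ADME assay on the whole organism (strain CD-1) for pharmacokinetics, with Mus musculus as the target, at a dose of 3 mg/kg by the intravenous route; on this read-out lower numbers stand for slow clearance and higher numbers for fast clearance:
- compound 1 `CN(Cc1ccccc1OCCCCC(C)(C)C(=O)O)C(=O)c1ccc(-c2ccco2)cc1`: 1.3 mL/min/kg
- compound 2 `C[C@@H](CCCOc1ccccc1CN(C)C(=O)c1ccc(-c2ccco2)cc1)CC(=O)O`: 1.3 mL/min/kg

Compound 2 stands level with compound 1, and neither value is a limit. In this assay, both numbers sit on the slow-clearance side of the read-out.

Compound 3 `CN(Cc1ccccc1OCCC[C@@H]1C[C@@H]1C(=O)O)C(=O)c1ccc(-c2ccco2)cc1` differs from compound 2 as follows: 2-carboxycyclopropyl in place of 1-(carboxymethyl)ethyl on a saturated chain carbon, three bonds along the chain from an oxygen on an aromatic ring. In words, this is 2-carboxycyclopropyl in place of 1-(carboxymethyl)ethyl on a saturated chain carbon, three bonds along the chain from an oxygen on an aromatic ring.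

Among the measured compounds shown here, only one measured step bears on this position: no change at the digits printed from compound 1 to compound 2 (within the scatter). It lies within the scatter and exchanges one open-chain carboxylic acid group for another. For the measured compounds named here, no measured compound carries the three-membered ring, so this single step is weak evidence for the new change, and the range must stay wide, with more room on the fast-clearance side.

The expected result in this assay is a 1.4-fold higher number from compound 2 to compound 3 (0.14 log units; within the scatter), which means no step beyond the scatter. The estimated value for compound 3 is 1.8 mL/min/kg, with an expected range from 0.7 mL/min/kg to 6 mL/min/kg.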

Compound 3, clearance: 1.7 mL/min/kg
Compound 3: the middle estimate sits 1.1-fold (0.02 log units) above what was measured; the measured number falls inside the stated range.
By their numbers in this assay, from the lowest: compounds 1, 2 and 3 (each within the scatter of the next).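

In this assay the series now holds an acid side chain with a three-membered ring of carbon only: putting 2-carboxycyclopropyl in place of 1-(carboxymethyl)ethyl gives a 1.3-fold higher number from compound 2 to compound 3 (0.12 log units; within the scatter) and putting it in place of 2-carboxy-2-methylpropyl gives a 1.3-fold higher number from compound 1 to compound 3 (0.12 log units; within the scatter) at the same place, on a saturated chain carbon, three bonds along the chain from an oxygen on an aromatic ring. Until now only open-chain groups had been compared here, so the finding is that the read-out also holds within the scatter when the open chain gives way to the ring, with compound 3 at 1.7 mL/min/kg still on the slow-clearance side. Nothing available explains why the three groups read alike.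

Among the compounds shown here, open is whether this level read-out depends on the particular arrangement of the defined stereocentres on the ring, since the series shows only the one form of 2-carboxycyclopropyl. Also open, going by these compounds, is what happens when a tetrazole or an amine replaces the carboxylic acid, or when a longer chain separates the acid from the oxygen on the aromatic ring.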